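Swapping the side chain on the five-membered ring for chlorine

The source may hold more compounds than are shown below. What is called first, only, known or untested is meant among the compounds shown, and "the series" means these compounds.

Measured compounds:
- compound 1, `COCc1c(C)nc2c(OCc3ccccc3)cccn12`: 99%
- compound 2, `Cc1nc2c(OCc3ccccc3)cccn2c1CS(C)(=O)=O`: 61%

Among the compounds with values here, compound 2 stands lowest of the two numbers in a functional assay on the whole organism with Rattus norvegicus as the target, with a stated time of 4 h, at a dose of 40 mg/kg by the intraperitoneal route (on this read-out higher numbers stand for more inhibition at the one dose given (going by the name of the read-out) and lower numbers for less inhibition), with compound 1 as its only neighbour at a number far above it. Within the data shown here, the one measured step, a number 38 percentage points lower from compound 1 to compound 2 (beyond the scatter), shows that what sits on this carbon of the five-membered ring can move the read-out strongly. The next compound, compound 3, `Cc1nc2c(OCc3ccccc3)cccn2c1Cl`, differs from compound 2 in one place: chloro in place of (methylsulfonyl)methyl on an aromatic carbon. Among the measured compounds shown here, no measured step uses chloro, so the size of the change is uncertain, but given the large swing seen in a number 38 percentage points lower from compound 1 to compound 2 (beyond the scatter) compound 3 is expected to move upward from compound 2, by an estimated a number 14 percentage points higher from compound 2 to compound 3 (beyond the scatter). For compound 3 the expected value in this assay is 75%, within an estimated range from 40% to 99%.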

Compound 3, a percentage reported as inhibition, in the whole organism at one dose (the size of the read-out at that dose, not a potency): 93%
For compound 3 the middle estimate is 18 percentage points below the measured one; the measured number falls inside the stated range.
By their numbers in this assay, from the lowest: compound 2; then compounds 3 and 1 (each within the scatter of the next).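

In this assay the step of a number 32 percentage points higher from compound 2 to compound 3 (beyond the scatter) shows that this aromatic carbon does not need a side chain for a high number: chloro, a single heavy atom with no hydrogen-bond acceptors, takes the place of the five heavy atoms of (methylsulfonyl)methyl. The step of a number 6 percentage points lower from compound 1 to compound 3 (within the scatter) lies within the scatter, so at this one dose chloro and methoxymethyl cannot be told apart. Among these three compounds, only the (methylsulfonyl)methyl group of compound 2 stands apart on this read-out, so the earlier drop belongs to that group and not to the loss of the methoxymethyl chain.

Nothing available explains these differences. As far as these compounds go, whether an amine, a carboxylic acid, a bromo group or a longer ether chain on this carbon would stay with chloro and methoxymethyl or fall with (methylsulfonyl)methyl remains open.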